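Trading a hydroxyl chain for a small cyclic ether

A few compounds are considered here, and "the series" means these few. Any claim that something is new, unique, unknown or untested is made for them only; others in the source may bear on it.

Of the compounds shown here, three built on one shared core have been measured in an ADME assay on microsomes from liver (Mus musculus, strain CD1) for metabolic stability, read by LC-MS, using NADPH, with a stated time of 60 min; a higher number here means that the compound lasts longer, a lower number that the compound disappears faster. Compound 1 `COc1ccc(-c2c(-c3ccc(OC)cc3)n(Cc3ccccc3)c3ncn(CCCO)c(=N)c23)cc1` gives 0.36 h in this assay. Compound 2 `COc1ccc(Cn2c(-c3ccccc3)c(-c3ccccc3)c3c(=N)n(CC4CCOCC4)cnc32)cc1` gives 0.217 h, and compound 3 `COc1ccc(Cn2c(-c3ccccc3)c(-c3ccccc3)c3c(=N)n(CCO)cnc32)cc1` gives 0.518 h. Among these three numbers compound 1 stands second highest; its gap to compound 3 and its gap to compound 2 both lie within the usual scatter of such measurements, so no order among the three can be read from them.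

Compound 4 `COc1ccc(-c2c(-c3ccc(OC)cc3)n(Cc3ccccc3)c3ncn(CC4CCOC4)c(=N)c23)cc1` has not yet been measured. It differs from compound 1 in one place: oxolan-3-yl in place of 2-hydroxyethyl on a saturated chain carbon bound to an aromatic nitrogen. Within the data shown here, one measured step bears on this kind of exchange, running in the opposite direction: a 2.4-fold higher number from compound 2 to compound 3 (0.38 log units; beyond the scatter). There a short hydroxyl-bearing chain in place of a saturated ring containing one oxygen went with a modestly higher number. Reading that step backwards, a modest drop in this assay is expected, a 1.8-fold lower number from compound 1 to compound 4 (0.26 log units; within the scatter). For compound 4 the expected value in this assay is therefore 0.2 h, with a likely range from 0.1 h to 0.4 h.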

Compound 4, half-life: 0.275 h
Compound 4: the middle estimate sits 1.4-fold (0.14 log units) below what was measured; the range from low to high includes it.
By their numbers in this assay, from the lowest: compounds 2, 4, 1 and 3 (each within the scatter of the next, the first and the last beyond it).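

In this assay, replacing 2-hydroxyethyl with oxolan-3-yl, which takes the count of hydrogen-bond donors in the group from 1 to 0, gives a 1.3-fold lower number from compound 1 to compound 4 (0.12 log units; within the scatter), so on the core of compound 1 this exchange leaves no readable difference. Among these compounds, the one earlier step of this kind, a 2.4-fold higher number from compound 2 to compound 3 (0.38 log units; beyond the scatter), lay beyond the scatter, but it involved a different ring, oxan-4-yl, and a different chain, hydroxymethyl, in another pair of compounds, so its size does not carry over to this pair. No measurement shown here bears on what lies behind either result.

Going by these compounds, it remains open how an amine or a carboxylic acid at the end of the chain, or a longer chain ending in a hydroxyl, would read at this place on a saturated chain carbon bound to an aromatic nitrogen. Also open, on these data alone, is how oxolan-3-yl would read on the core of compound 3, which would show whether the two ring exchanges differ through the ring itself or through the rest of the molecule.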